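Methoxy for Methylsulfanyl: One Change, One Expectation

The source may report more compounds than this note shows. Statements on the series, on what has been measured and on what is new or still open speak of the compounds shown alone.

Of the compounds shown here, two have so far been measured in a functional assay on the whole organism for inhibition, with Digitaria ciliaris as the target, with a stated time of 72 h, tested at 100 mg/L; a higher number here means more inhibition of growth at the concentration tested, a lower number less inhibition of growth. Compound 1 `COc1cc(SC)nc(NC(=S)NC(=O)c2c(-c3ccc(Cl)cc3Cl)noc2C)n1` gives 55.6% in this assay, while compound 2 `COc1cc(OC)n2s/c(=N\C(=O)c3c(-c4ccc(Cl)cc4Cl)noc3C)nc2n1`, which carries a different, ring-fused arrangement, gives 85.3%. Of these two numbers compound 1 stands lowest, and its gap to compound 2 lies beyond the usual scatter of repeated measurements. Since the two structures differ in more than one place, no single step can be read off between them.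

Compound 3 `COc1cc(OC)nc(NC(=S)NC(=O)c2c(-c3ccc(Cl)cc3Cl)noc2C)n1` is not yet measured. It differs from compound 1 in one place: methoxy in place of methylsulfanyl on an aromatic carbon. For the measured compounds named here, no measured pair shows this same exchange, so there is no step to lean on. The change is expected to shift the number little, if at all, and the step from compound 1 to compound 3 is estimated as a number 4.4 percentage points higher from compound 1 to compound 3 (within the scatter), within the scatter. Compound 3 is therefore expected to give 60%, with a range from 40% to 80%.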

Compound 3, percent growth inhibition at one concentration: 65.9%
The estimate for compound 3 lay 5.9 percentage points below the measured number; low and high end bracket the measured number.
By their numbers in this assay, from the lowest: compound 1; then compound 3; then compound 2.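

In this assay, for the compounds shown here, the first step that can be read at this position is a number 10.3 percentage points higher from compound 1 to compound 3 (beyond the scatter), so the group on this aromatic carbon, next to the ring nitrogen, does change the result. Methylsulfanyl and methoxy have the same count of heavy atoms and hydrogen-bond acceptors, so the step comes with an exchange of sulfur for oxygen while those counts stay the same. Nothing available shows why the oxygen-bearing 4,6-dimethoxypyrimidin-2-yl compound inhibits growth more.

This single pair cannot show how a different group at this position, such as an amine or a longer chain like butoxy, would behave. It also leaves open whether the same exchange would give a similar step on a different core, such as the ring-fused arrangement of compound 2.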